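The source may hold more compounds than are shown below. What is called first, only, known or untested is meant among the compounds shown, and "the series" means these compounds.

Compound 1, `COc1ccc2occ(CSC(=S)N3CCCCC3)c(=O)c2c1`, was tested in a functional assay on HEp-2 cells (Homo sapiens) for antiproliferative activity, read by MTT assay, with a stated time of 72 h (on this read-out lower numbers stand for stronger inhibition and higher numbers for weaker inhibition), and gave 4300 nM. Among the three compounds measured there, compound 1 holds the second highest number. Its nearest neighbour is compound 3, `CCOC(=O)c1cc(=O)c2cc(CSC(=S)N(C(C)C)C(C)C)ccc2o1`, which in this assay gives 15900 nM, a higher number that lies beyond the usual scatter. The furthest is compound 2, `O=c1c(CSC(=S)N2CCCCC2)coc2cc(Cl)ccc12`, which gives 280 nM, a lower number, again beyond the scatter. Neither of these two compounds differs from compound 1 in a single place, so no clean step can be read from them.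

The unmeasured compound 4, `COc1ccc2occ(CSC(=S)N3CCOCC3)c(=O)c2c1`, differs from compound 1 in one place: morpholin-4-yl in place of piperidin-1-yl on a thiocarbonyl carbon. Within the data shown here, no measured pair shows this kind of change, so the size of the step from compound 1 to compound 4 is not known from the data. The expectation is a small step, if any, probably toward a higher number and not far beyond the scatter, written as a 1.4-fold higher number from compound 1 to compound 4 (0.14 log units; within the scatter). Compound 4 is therefore estimated at 6000 nM in this assay, with a range from 2000 nM to 18000 nM.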

Compound 4, half-maximal inhibitory concentration: 4800 nM
Compound 4: the middle estimate sits 1.3-fold (0.10 log units) above what was measured; measured number inside the range.
By their numbers in this assay, from the lowest: compound 2; then compounds 1 and 4 (each within the scatter of the next); then compound 3.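

Morpholin-4-yl in place of piperidin-1-yl on a thiocarbonyl carbon gives a 1.1-fold higher number from compound 1 to compound 4 (0.05 log units; within the scatter) in this assay, the first step among these compounds that can be read in one place. On this core, the entry of a second hetero atom into the six-membered ring and of a hydrogen-bond acceptor therefore leaves two compounds that this read-out cannot tell apart. No measurement shown offers a reason for this result.

From the compounds shown here alone, whether the same holds for piperazin-1-yl, with its second ring nitrogen, or for an open-chain group such as dimethylamino at this place remains open. Also open, going by these compounds, is whether morpholin-4-yl would read the same way on the core of compound 2, which gives 280 nM, as it does on the core of compound 1.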